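Working notes: from compound 2 to compound 3

The source may hold more compounds than are shown below. What is called first, only, known or untested is meant among the compounds shown, and "the series" means these compounds.

- compound 1 (`Cc1ccc(C)c(N2CCN(C(=O)c3oc(C)nc3-c3ccccc3F)CC2)c1`): 319 nM
- compound 2 (`Cc1nc(-c2ccccc2)c(C(=O)N2CCN(c3ccccc3Cl)CC2)o1`): 124 nM

In a functional assay on HL-60 cells (Homo sapiens) for inhibition, read by MTT assay, with a stated time of 72 h (a lower number here means a stronger inhibitor, a higher number a weaker inhibitor), compound 2 (124 nM) holds the lower of the two numbers, and its gap to compound 1 (319 nM) lies beyond the scatter. The unmeasured compound 3 (`Cc1nc(-c2ccccc2)c(C(=O)N2CCN(c3c(C)cccc3C)CC2)o1`) has 2,6-dimethylphenyl in place of 2-chlorophenyl on an amine nitrogen in a ring. Within the data shown here, no measured pair isolates this change, so the data do not fix its size. A modest weakening is expected (a 2.0-fold higher number from compound 2 to compound 3 (0.30 log units; within the scatter)), and it may not clear the scatter. The estimated value for compound 3 is 250 nM (expected range 70 nM to 800 nM).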

Compound 3, half-maximal inhibitory concentration: 146 nM
The estimate for compound 3 lay 1.7-fold (0.23 log units) above the measured number, within the range that was stated.
By their numbers in this assay, from the lowest: compounds 2 and 3 (each within the scatter of the next); then compound 1.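

In this assay, 2,6-dimethylphenyl in place of 2-chlorophenyl on the amine nitrogen in a ring gives a 1.2-fold higher number from compound 2 to compound 3 (0.07 log units; within the scatter). Among these compounds, this is the first single-place step, and it shows that chlorine is not needed at this position to keep the number of compound 2: the all-carbon group of compound 3 stands level with it. No supporting data bear on why the two groups match. Still open, going by these compounds, is whether a carboxylic acid or a methoxy group on this phenyl ring would stay in the same range.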